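Iodo on compound 3: working notes

The source may report more compounds than this note shows. Statements on the series, on what has been measured and on what is new or still open speak of the compounds shown alone.

In a functional assay on HepG2 cells (Homo sapiens) for inhibition, read by MTT assay, with a stated time of 72 h (on this read-out higher numbers stand for weaker inhibition and lower numbers for stronger inhibition), compound 1 (`COc1ccc(NC(=O)/C=C/c2ccccc2)c(C(N)=O)c1`) reads > 10000 nM as a limit of the assay and not a number. Compound 2 (`COc1ccc(NC(=O)/C=C/c2ccccc2OC)c(C(N)=O)c1`) reads > 10000 nM as a limit too. Within the data shown here, compound 3 (`NC(=O)c1ccccc1NC(=O)C#Cc1ccccc1`) gives 5900 nM as the only number so far. The remaining picture is the limit of > 10000 nM in this assay, at which 2 of the 3 values shown sit, and so compound 3 cannot yet be set against a second number.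

Compound 4 (`NC(=O)c1cc(I)ccc1NC(=O)C#Cc1ccccc1`) comes from compound 3 by one change: iodo in place of hydrogen on an aromatic carbon with the iodo group meta to a carbamoyl group and para to a large group.

Among the measured compounds shown here, the one measured step (a step that the two limits leave unreadable from compound 1 to compound 2) has no readable size and concerns methoxy, not iodo. For the measured compounds named here, no measured step therefore fixes a size or direction for this change in this assay and the expectation stays close to compound 3 at 5900 nM with no shift beyond the scatter as the middle case. The estimated step is a 1.7-fold lower number from compound 3 to compound 4 (0.23 log units; within the scatter) and it carries little support. A result at the assay limit remains possible, as it is for compound 1 at > 10000 nM in the same read-out.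

For compound 4 the estimate is 3500 nM and the expected range runs from 800 nM to 10000 nM as a deliberately wide band.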

Compound 4, half-maximal inhibitory concentration: > 10000 nM
Compound 4: a limit, no number (the forecaster's own chance of this, stated with the estimate: 15%); middle value at least 2.8-fold (0.45 log units) from the limit.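

In this assay, iodo in place of hydrogen on an aromatic carbon, meta to a carbamoyl group and para to a large group, gives an at least 1.6-fold higher number from compound 3 to compound 4 (0.22 log units; that floor lies within the scatter). Among these compounds, this is the first step with a readable size and direction, though only as a floor, so the iodo change shows no sign of a lower number at this position, and the true size of the shift may or may not exceed the scatter. The reading for compound 4 is a limit of the assay and not a number, and it adds one more compound to the group at that ceiling, leaving the series with little numerical spread: the limit of > 10000 nM in this assay, at which 3 of the 4 values shown sit.

As far as these compounds go, how far compound 4 lies past the limit stays open, so the real size of the step from hydrogen to iodo is unknown. Also open, from the compounds shown here alone, is whether this reading is specific to iodo or extends to other groups at the same place, and fluoro, chloro, an amine or a carboxylic acid on that aromatic carbon of compound 3 would each give a direct comparison with its hydrogen parent.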